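This account rests on a few compounds, and the source may have more. Where it says the series, first, only, none or still open, it means among the compounds named here.

Four compounds share one core and differ only in the aryl group that sits on a double-bonded chain carbon bound to a double-bonded ring carbon. Compound 1 `CC(=O)OC[C@H]1O[C@@H](n2cc(CN3C(=O)/C(=C\c4ccc(C)cc4)c4ccccc43)nn2)[C@H](OC(C)=O)[C@@H](OC(C)=O)[C@@H]1OC(C)=O` carries a 4-methylphenyl there, and in an ADME assay on NIH3T3 cells (Homo sapiens) for cytotoxicity, read by sulforhodamine B assay, with a stated time of 48 h (on this read-out lower numbers stand for stronger inhibition and higher numbers for weaker inhibition), compound 1 gives 9000 nM. Compound 3 `CC(=O)OC[C@H]1O[C@@H](n2cc(CN3C(=O)/C(=C\c4ccc5ccccc5c4)c4ccccc43)nn2)[C@H](OC(C)=O)[C@@H](OC(C)=O)[C@@H]1OC(C)=O` carries a naphthalen-2-yl, and in this assay compound 3 gives 80000 nM, the higher of the two numbers measured; the step of an 8.9-fold higher number from compound 1 to compound 3 (0.95 log units; beyond the scatter). Compound 2 `COc1ccc(/C=C2\C(=O)N(Cc3cn([C@@H]4O[C@H](COC(C)=O)[C@@H](OC(C)=O)[C@H](OC(C)=O)[C@H]4OC(C)=O)nn3)c3ccccc32)cc1OC` carries a 3,4-dimethoxyphenyl, and in this assay compound 2 reaches only a limit of the assay, > 100000 nM. Put as steps, an at least 11-fold higher number from compound 1 to compound 2 (1.04 log units; beyond the scatter), while an at least 1.2-fold lower number from compound 2 to compound 3 (0.09 log units; that floor lies within the scatter). Compound 4 `CC(=O)OC[C@H]1O[C@@H](n2cc(CN3C(=O)/C(=C\c4cccs4)c4ccccc43)nn2)[C@H](OC(C)=O)[C@@H](OC(C)=O)[C@@H]1OC(C)=O` is not yet measured; it differs from compound 3 in that (thiophen-2-yl in place of naphthalen-2-yl on a double-bonded chain carbon bound to a double-bonded ring carbon). All three measured steps exchange this same aryl group, and the two that left the scatter raised the number on going from the 4-methylphenyl of compound 1 to the larger groups of compound 2 and compound 3. Thiophen-2-yl is a single five-membered ring, so a lower number than that of compound 3 is expected, though no measured step removes a ring as this one does. For compound 4 the expected step is a 4.0-fold lower number from compound 3 to compound 4 (0.60 log units; beyond the scatter), giving an estimate of 20000 nM, with a range from 5000 nM to 100000 nM.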

Compound 4, half-maximal inhibitory concentration: 14600 nM
Compound 4: middle estimate off by 1.4-fold (0.14 log units), on the high side, and the stated range covers the measured number.
By their numbers in this assay, from the lowest: compounds 1 and 4 (each within the scatter of the next); then compound 3. At a limit, above all of these: compound 2.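

Compound 4 shows that this position can tolerate a group other than 4-methylphenyl without the number leaving the scatter in this assay: a 1.6-fold higher number from compound 1 to compound 4 (0.21 log units; within the scatter). It also shows that the rise seen with larger groups can be undone by a change at this same place, with a 5.5-fold lower number from compound 3 to compound 4 (0.74 log units; beyond the scatter), although ring count alone does not sort the series, since the single-ring 3,4-dimethoxyphenyl of compound 2 goes against it. The step of an at least 6.8-fold lower number from compound 2 to compound 4 (0.83 log units; beyond the scatter) gives only a floor, as compound 2 stands at a limit of the assay: the limit of > 100000 nM in this assay, at which 1 of the 4 values shown sits.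

From the compounds shown here alone, whether a pyridine ring or a plain methyl on a double-bonded chain carbon bound to a double-bonded ring carbon would keep the number near that of compound 1 or compound 4 stays open. So does the effect of an amine or a carboxylic acid on the aryl group.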